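The compounds below may be only part of what the source reports. "The series", "measured", "known", "first", "only" and "open" are said of these compounds alone.

Among the compounds with values here, compound 1 `COc1cc([C@@H]2C[C@@]2(CO)C(=O)Nc2ccccc2)cc(OC)c1OC` gives 43200 nM in a functional assay on A549 cells (Homo sapiens) for cytotoxicity, read by MTT assay, with a stated time of 48 h (a higher number here means a weaker inhibitor, a lower number a stronger inhibitor), the only single number among the three compounds measured there. Compound 3 `COc1cc([C@H]2C[C@@]2(CO)C(=O)Nc2ccccc2)cc(OC)c1OC` is reported as > 100000 nM, which is a limit and not a number. Compound 2 `CCOC(=O)C1(C(=O)NCc2ccccc2)CC1c1cc(OC)c(OC)c(OC)c1` gives 79500 nM; > 100000 nM (2 entries), so it has several entries and no single number.

Within the data shown here, the one measured step is an at least 2.3-fold higher number from compound 1 to compound 3 (0.36 log units; beyond the scatter). Given (the fact that compounds 1 and 3 differ only in the configuration as drawn), that step speaks to configuration and says nothing direct about the amide substituent.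

Compound 4 `COc1cc([C@@H]2C[C@@]2(CO)C(=O)NCc2ccc(C)cc2)cc(OC)c1OC` keeps the core of compound 1 and carries 4-methylbenzyl in place of phenyl on an amide-type nitrogen. Among the measured compounds shown here, no measured step isolates this change. The nearest guide is compound 2, which also lacks the anilino group but differs from compound 1 elsewhere too. The evidence from compound 2 is the several entries of compound 2 in this assay, 79500 nM; > 100000 nM (2 entries), and it points towards a higher number in this assay, though only loosely.

A modest move in that direction is expected, and a report as a limit would be no surprise. The expected change is a 2.1-fold higher number from compound 1 to compound 4 (0.32 log units; beyond the scatter). For compound 4 the estimated value is 90000 nM, with an expected range of 40000 nM to 170000 nM.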

Compound 4, half-maximal inhibitory concentration: 46300 nM
Estimate against measurement, compound 4: 1.9-fold (0.29 log units) above, and the stated range covers the measured number.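

In this assay, replacing phenyl with 4-methylbenzyl on the amide-type nitrogen gives a 1.1-fold higher number from compound 1 to compound 4 (0.03 log units; within the scatter), so the two compounds cannot be told apart and this change leaves the read-out within the scatter. Within the data shown here, this is the first measured step at the amide substituent, as the only earlier step spoke to configuration alone: the fact that compounds 1 and 3 differ only in the configuration as drawn. With the core of compound 1 held constant, the step also gives a cleaner reading of this position than compound 2, which differs from compound 1 in more than one place, and whose entries cannot be assigned to the amide substituent alone: the several entries of compound 2 in this assay, 79500 nM; > 100000 nM (2 entries).

The compounds shown do not separate the contribution of the methyl group from that of the benzyl unit, and they do not show whether a carboxylic acid or an amine in place of that methyl group would leave the number unchanged. Among these compounds, they also leave open whether the stereocentre at the saturated ring carbon matters with 4-methylbenzyl as it does with phenyl, since the single step on configuration belongs to the phenyl pair.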